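Replacing 3-chlorophenyl with pyridin-3-yl in compound 3

A few compounds are considered here, and "the series" means these few. Any claim that something is new, unique, unknown or untested is made for them only; others in the source may bear on it.

In a functional assay on DU-145 cells (Homo sapiens) for cytotoxicity, read by ELISA, with a stated time of 4 days (on this read-out lower numbers stand for stronger inhibition and higher numbers for weaker inhibition), compound 1 (`Cc1ccsc1-c1cc(-c2ccco2)cc(-c2ccccc2Cl)n1`) gives 29900 nM and compound 2 (`Cc1ccsc1-c1cc(-c2ccco2)cc(-c2ccc(Cl)cc2)n1`) gives 26700 nM and compound 3 (`Cc1ccsc1-c1cc(-c2ccc(Cl)o2)cc(-c2cccc(Cl)c2)n1`) gives 20500 nM so that all three lie within the usual scatter of one another. Compound 4 (`Cc1ccsc1-c1cc(-c2ccc(Cl)o2)cc(-c2cccnc2)n1`) has pyridin-3-yl in place of the 3-chlorophenyl of compound 3 on an aromatic carbon, a change counted as pyridin-3-yl in place of 3-chlorophenyl on an aromatic carbon and still untested. Within the data shown here, the only measured step at a single place is a 1.1-fold lower number from compound 1 to compound 2 (0.05 log units; within the scatter) and it merely puts 4-chlorophenyl in place of 2-chlorophenyl, so no measurement shows what replacing a chlorophenyl with pyridin-3-yl does. No step beyond the scatter is therefore expected in this assay in either direction, on thin evidence. The expected change is a 1.2-fold higher number from compound 3 to compound 4 (0.09 log units; within the scatter) on this reasoning. For compound 4 the estimated value is 25000 nM with a range from 10000 nM to 60000 nM around it.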

Compound 4, half-maximal inhibitory concentration: 30800 nM
Estimate against measurement, compound 4: 1.2-fold (0.09 log units) below; the measured number falls inside the stated range.
By their numbers in this assay, from the lowest: compounds 3, 2, 1 and 4 (each within the scatter of the next).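

Among these compounds, this is the first measured swap at this position of a chlorophenyl for a ring carrying a nitrogen, and in this assay it amounts to a 1.5-fold higher number from compound 3 to compound 4 (0.18 log units; within the scatter). Losing the chlorine and gaining a hydrogen-bond acceptor, by the count of the two groups, thus moves the number no further than repeat measurements would. No accompanying measurement bears on this result.

Still open, on these data alone, is whether any group at this position can produce a step beyond the scatter. An amine or a carboxylic acid there would test this.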